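This account rests on a few compounds, and the source may have more. Where it says the series, first, only, none or still open, it means among the compounds named here.

Measured compounds:
- compound 1, `Nc1ccc(-c2cc(=O)c3c(N)c(F)c(O)c(F)c3o2)cc1F`: > 100000 nM
- compound 2, `Nc1ccc(-c2cc(=O)c3c(N)c(F)c(CO)c(F)c3o2)cc1F`: 24000 nM

Both were tested in a functional assay on HeLa cells (Homo sapiens) for cytotoxicity, read by neutral red uptake, with a stated time of 3 days; on this read-out higher numbers stand for weaker inhibition and lower numbers for stronger inhibition. For compound 1 the result of > 100000 nM is a limit of the assay rather than a number. Compound 2, in this assay, gives 24000 nM. The change between them, hydroxymethyl in place of hydroxy on an aromatic carbon, gave an at least 4.1-fold lower number from compound 1 to compound 2 (0.61 log units; beyond the scatter); this rests on (the limit of > 100000 nM in this assay, at which 1 of the 2 values shown sits). For the measured compounds named here, compound 2 therefore stands as the only compound with a number in this assay, the other result being a limit.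

Compound 3 is `CCOC(=O)c1c(F)c(N)c2c(=O)cc(-c3ccc(N)c(F)c3)oc2c1F`. Its difference from compound 2 is ethoxycarbonyl in place of hydroxymethyl on an aromatic carbon. Going by the values given here, the one measured step touches the same aromatic carbon but exchanges a different pair of groups, so it offers only loose guidance for this change. Among the compounds with values here, no measured step shows what ethoxycarbonyl does here, so no shift beyond the scatter is expected in this assay, in either direction. For compound 3 in this assay the estimate is 30000 nM, with a range from 8000 nM to 150000 nM, which means an expected step of a 1.3-fold higher number from compound 2 to compound 3 (0.10 log units; within the scatter).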

Compound 3, half-maximal inhibitory concentration: > 100000 nM
Compound 3: only a limit was reported; the forecaster's own chance of this, stated with the estimate: 30%; at least 3.3-fold (0.52 log units) between middle value and limit.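

At this aromatic carbon, ortho to two fluoro groups, putting ethoxycarbonyl in place of hydroxymethyl gave an at least 4.1-fold higher number from compound 2 to compound 3 (0.61 log units; beyond the scatter) in this assay, so the measurable effect of compound 2 does not carry over to this larger ester group. Compound 3 thus joins compound 1 at a limit of the assay, and among the three groups shown at this carbon, only hydroxymethyl gives a measured number. The step between compound 1 and compound 3 cannot be read, and the comparison across this series depends heavily on a limit: the limit of > 100000 nM in this assay, at which 2 of the 3 values shown sit.

The compounds shown leave open how far the true value of compound 3 lies past its limit, so the full size of the step from hydroxymethyl to ethoxycarbonyl remains unknown. They also leave open whether a carboxylic acid, an amide or an aminomethyl group at this same carbon would give a measured number in this assay, and so whether hydroxymethyl is unusual here or one of several groups that would do so.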